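The compounds below may be only part of what the source reports. "The series", "measured", "known", "first", "only" and "open" are said of these compounds alone.

Measured so far:
Compound 1, `CCCCCSc1nc(NCc2ccc([Se]C)cc2)c2ccccc2n1`, gives > 100000 nM in an ADME assay on 184B5 cells (Homo sapiens) for cytotoxicity, read by MTT assay, with a stated time of 72 h (a lower number here means a stronger inhibitor of growth, a higher number a weaker inhibitor of growth), a value that is a limit of the assay and not a number.
Compound 2, `CSc1nc(NCc2ccc([Se]C)cc2)c2ccccc2n1`, gives > 100000 nM in this assay, again a limit and not a number.
Compound 3, `CCCCC[Se]c1nc(N)c2cccnc2n1`, gives 40200 nM in this assay.

Compound 1 and compound 2 share one core and differ in a single place: hydrogen in place of butyl on a saturated chain carbon bound to a sulfur. Both of their values sit at a limit, so the step that the two limits leave unreadable from compound 1 to compound 2 cannot be sized; it stays unreadable because the limit of > 100000 nM in this assay, at which 2 of the 3 values shown sit, caps both ends of it.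

Compound 3 is built on a different core, and the difference between the cores of compound 3 and compound 1 is not broken down here. Compound 4, `C[Se]c1nc(N)c2cccnc2n1`, has not yet been measured. It differs from compound 3 in one place: hydrogen in place of butyl on a saturated chain carbon bound to a selenium atom. For the measured compounds named here, this is the same kind of change as the one from compound 1 to compound 2, but not the same change: there the place is a saturated chain carbon bound to a sulfur, here it is a saturated chain carbon bound to a selenium atom.

Going by the values given here, with the only measured example of this change unreadable, the expectation for compound 4 rests on compound 3 alone and its value 40200 nM. For compound 4 the expected step is a 1.7-fold higher number from compound 3 to compound 4 (0.24 log units; within the scatter), a guess that leans toward weaker growth inhibition but allows for no change at all. The estimate for compound 4 in this assay is 70000 nM, expected to lie between 25000 nM and 200000 nM.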

Compound 4, concentration for total growth inhibition: 87200 nM
Estimate against measurement, compound 4: 1.2-fold (0.10 log units) below; measured number inside the range.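

Putting hydrogen in place of butyl on a saturated chain carbon bound to a selenium atom, which is the same difference as pentyl to methyl, gives a 2.2-fold higher number from compound 3 to compound 4 (0.34 log units; beyond the scatter) in this assay, so on this core the methyl compound is the weaker inhibitor of growth. The same kind of change on the core of compound 1, there on a saturated chain carbon bound to a sulfur, cannot be read, because compound 1 and compound 2 both sit at a limit of the assay and not at a number: the limit of > 100000 nM in this assay, at which 2 of the 4 values shown sit. That leaves one readable example on one core, so it shows what the change does here but not whether a step of this size or direction carries over to another core, where the chain is also bound to a different atom.

The compounds shown leave open whether the number climbs gradually or changes abruptly between pentyl and methyl, which an ethyl or a propyl chain on the selenium atom could help to settle. Also open, on these data alone, is how a longer chain such as octyl, or an amine or a carboxylic acid in place of the pentyl, would compare in this assay.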